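A few compounds are considered here, and "the series" means these few. Any claim that something is new, unique, unknown or untested is made for them only; others in the source may bear on it.

Measured so far:
compound 1 `CCCCCc1ccc(C#Cc2c(-c3ccc(CCCCC)cc3)oc3nc(=O)n(Cc4cn(-c5ccccc5F)nn4)cc23)cc1`, which gives 72500 nM;
compound 2 `CCCCCCC#Cc1c(CCCCCC)oc2nc(=O)n(Cc3cn(-c4ccc(F)cc4)nn3)cc12`, which gives > 100000 nM.

For the measured compounds named here, in a functional assay on HepG2 cells (Homo sapiens) for antiproliferative activity, read by MTT assay, with a stated time of 72 h (on this read-out lower numbers stand for stronger inhibition and higher numbers for weaker inhibition), compound 1 gives 72500 nM, the only number recorded among the two values. For compound 2 the entry of > 100000 nM is a limit of this assay and not a number, as noted in the limit of > 100000 nM in this assay, at which 1 of the 2 values shown sits. Going by the values given here, the two compounds differ in several places at once, so no single step between them can be read; their values show only that compound 1 returns a number where compound 2 does not.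

The unmeasured compound 3 `CCCCCc1ccc(C#Cc2c(-c3ccc(CCCCC)cc3)oc3nc(=O)n(Cc4cn(Cc5ccccc5)nn4)cc23)cc1` shares the core and both pentyl-bearing aryl groups of compound 1 and differs from it in one place: benzyl in place of 2-fluorophenyl on an aromatic nitrogen. Among the compounds with values here, with no measured step of this kind available, the change from compound 1 to compound 3 is expected to stay within the usual scatter of this assay, with no direction favoured, so the step of a 1.0-fold lower number from compound 1 to compound 3 (0.02 log units; within the scatter) is estimated as small. Compound 3 is accordingly expected to give about 70000 nM, within a range from 30000 nM to 160000 nM.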

Compound 3, half-maximal inhibitory concentration: > 100000 nM
Compound 3: a limit, no number; the forecaster's own chance of this, stated with the estimate: 30%; at least 1.4-fold (0.15 log units) between middle value and limit.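

In this assay, the one single-place change shown, benzyl in place of 2-fluorophenyl on an aromatic nitrogen, gives an at least 1.3-fold higher number from compound 1 to compound 3 (0.13 log units; that floor lies within the scatter). For compound 3 the entry > 100000 nM is a limit of the assay and not a number. The step therefore has only a floor, which does not show that this position responds to the change beyond the scatter, and its true size stays unfixed, with compound 1 still the only compound returning a number: the limit of > 100000 nM in this assay, at which 2 of the 3 values shown sit.

The compounds shown leave open whether another group on this aromatic nitrogen, such as an aminoethyl chain or a carboxylic acid-bearing phenyl, would give a clearly lower number than compound 1 in this assay. They also leave open how plain phenyl at this position would compare with 2-fluorophenyl and benzyl.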